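The Same Swap Tried on a Second Core

This account rests on a few compounds, and the source may have more. Where it says the series, first, only, none or still open, it means among the compounds named here.

Compound 1 `COc1ccc(CNC(=O)/C(C#N)=C/c2ccc3ccccc3c2)cc1` and compound 2 `COc1ccc(CNC(=O)/C(C#N)=C/c2cccc3ccccc23)cc1` are built from the same atoms joined differently; how the two cores differ is not broken down here. In a functional assay on BE(2)-C cells (Homo sapiens) for inhibition, read by MTT assay, with a stated time of 72 h (on this read-out higher numbers stand for weaker inhibition of growth and lower numbers for stronger inhibition of growth), compound 1 gives 42000 nM, and compound 2 gives 14000 nM, the lowest of the three measured values. Compound 3 `N#C/C(=C\c1ccc2ccccc2c1)C(=O)NCc1ccc(Cl)c(Cl)c1` differs from compound 1 by 3,4-dichlorophenyl in place of 4-methoxyphenyl on a saturated chain carbon bound to an amide-type nitrogen, and in this assay compound 3 gives 40000 nM, so the step of a 1.1-fold lower number from compound 1 to compound 3 (0.02 log units; within the scatter) is small. Compound 4 `N#C/C(=C\c1cccc2ccccc12)C(=O)NCc1ccc(Cl)c(Cl)c1`, not yet measured, differs from compound 2 by 3,4-dichlorophenyl in place of 4-methoxyphenyl on a saturated chain carbon bound to an amide-type nitrogen, the same change at the same place. The expected step is a 1.1-fold lower number from compound 2 to compound 4 (0.03 log units; within the scatter) because the same change gave a 1.1-fold lower number from compound 1 to compound 3 (0.02 log units; within the scatter). Compound 4 is therefore expected to give about 13000 nM, most likely between 5000 nM and 35000 nM.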

Compound 4, concentration for 50% growth inhibition: 7000 nM
The estimate for compound 4 lay 1.9-fold (0.27 log units) above the measured number; low and high end bracket the measured number.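

Putting 3,4-dichlorophenyl in place of 4-methoxyphenyl gives a 2.0-fold lower number from compound 2 to compound 4 (0.30 log units; within the scatter) in this assay. Set beside the earlier step, the change carries over from one core to the other with no difference that can be told from the scatter: the same change on two cores in this assay, a 1.1-fold lower number (0.02 log units; within the scatter) from compound 1 to compound 3 and a 2.0-fold lower number (0.30 log units; within the scatter) from compound 2 to compound 4, 1.9-fold (0.28 log units) apart, within the scatter of two such steps. This does not show that the swap strengthens growth inhibition, since neither step lies beyond the scatter, and two pairs of compounds give no rule for other cores.

The compounds shown leave open whether a different group on the saturated chain carbon bound to the amide-type nitrogen, such as an amine or a carboxylic acid, would shift the number beyond the scatter.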